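This account rests on a few compounds, and the source may have more. Where it says the series, first, only, none or still open, it means among the compounds named here.

Measured so far:
- compound 3 `O=C(CN1CN(c2ccccc2)C2(CCN(C(=O)c3ccc(C4CCCCC4)cc3)CC2)C1=O)N1CCCCC1` gives 1100 nM in an assay on HEK293 cells for displacement of a labelled ligand from NPC1-like intracellular cholesterol transporter 1 (Homo sapiens); a higher number here means a weaker inhibitor, a lower number a stronger inhibitor
- compound 1 `COC(=O)CCCNC(=O)CN1CN(c2ccccc2)C2(CCN(C(=O)c3ccc(C4CCCCC4)cc3)CC2)C1=O` gives 2500 nM in this assay
- compound 2 `CS(=O)(=O)N1CCN(C(=O)CN2CN(c3ccccc3)C3(CCN(C(=O)c4ccc(C5CCCCC5)cc4)CC3)C2=O)CC1` gives 6300 nM in this assay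

Compound 3 has the lowest number of the three and is therefore the strongest inhibitor in this set: the step is a 2.3-fold lower number from compound 1 to compound 3 (0.36 log units; beyond the scatter), and a 5.7-fold lower number from compound 2 to compound 3 (0.76 log units; beyond the scatter). Compound 4 `CC1(C)CC(OC(=O)CN2CN(c3ccccc3)C3(CCN(C(=O)c4ccc(C5CCCCC5)cc4)CC3)C2=O)CC(C)(C)N1` is not yet measured. It differs from compound 3 only at the group attached to the carbonyl carbon: (2,2,6,6-tetramethylpiperidin-4-yl)oxy in place of piperidin-1-yl on a carbonyl carbon.

All three measured steps concern exchanges at this same carbonyl carbon, and each was modest: a 2.5-fold higher number from compound 1 to compound 2 (0.40 log units; beyond the scatter), a 2.3-fold lower number from compound 1 to compound 3 (0.36 log units; beyond the scatter) and a 5.7-fold lower number from compound 2 to compound 3 (0.76 log units; beyond the scatter). The pattern among these three compounds is that the simple piperidin-1-yl amide of compound 3 sits lowest, while the groups of compound 1 and compound 2, which carry more hetero atoms, sit higher. The incoming (2,2,6,6-tetramethylpiperidin-4-yl)oxy group is larger than piperidin-1-yl and brings a hydrogen-bond donor and two acceptors, more like compound 1 in that respect. A modest rise in the number for compound 4 is therefore expected, on the order of a 2.7-fold higher number from compound 3 to compound 4 (0.44 log units; beyond the scatter), though an exact match to compound 3 cannot be ruled out. The estimate for compound 4 is 3000 nM, with a range from 1000 nM to 9000 nM.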

Compound 4, half-maximal inhibitory concentration: 600 nM
For compound 4 the middle estimate is 5.0-fold (0.70 log units) above the measured one, outside the stated range (below it).
By their numbers in this assay, from the lowest: compounds 4 and 3 (each within the scatter of the next); then compound 1; then compound 2.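

The exchange of piperidin-1-yl for (2,2,6,6-tetramethylpiperidin-4-yl)oxy on this carbonyl carbon gives a 1.8-fold lower number from compound 3 to compound 4 (0.26 log units; within the scatter) in this assay, so compound 3 and compound 4 cannot be told apart here, and the larger group is tolerated at this place. Set against the other two groups, the same incoming group gives an 11-fold lower number from compound 2 to compound 4 (1.02 log units; beyond the scatter) and a 4.2-fold lower number from compound 1 to compound 4 (0.62 log units; beyond the scatter), which shows that a group carrying a hydrogen-bond donor and hydrogen-bond acceptors can still match the simple ring of compound 3, so the earlier link between more hetero atoms and a higher number does not hold for compound 4. Nothing measured here gives a reason for this result.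

Going by these compounds, compound 4 changes two things at once compared with compound 3, the oxygen link to the carbonyl carbon and the ring with its methyl groups, so the contribution of each stays unknown. On these data alone, a (2,2,6,6-tetramethylpiperidin-4-yl)amino group on the same carbonyl carbon, or a piperidin-4-yloxy group without the methyl groups, would separate the two, and how a carboxylic acid would fare at this place also remains open.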